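Cyclohexyl in place of pentan-3-yl on the shared core

The source may hold more compounds than are shown below. What is called first, only, known or untested is meant among the compounds shown, and "the series" means these compounds.

Values so far in an ADME assay on microsomes from liver (Homo sapiens) for metabolic stability (on this read-out higher numbers stand for a longer-lived compound and lower numbers for a shorter-lived compound), are these.
- Compound 1 `CC(C)C(/C=C1\NC(=O)NC1=O)c1ccc(-c2ccc3cccc(F)c3c2)[nH]c1=O` gives > 3 h, a limit.
- Compound 2 `CC(C)C(c1ccc(-c2ccc3cccc(F)c3c2)[nH]c1=O)C1NC(=O)NC1=O` gives 0.578 h.
- Compound 3 `CCC(CC)C(/C=C1\OC(=O)NC1=O)c1ccc(-c2ccc3cccc(F)c3c2)[nH]c1=O` gives > 3 h, a limit.

Compound 3 therefore has no exact number, only (the limit of > 3 h in this assay, at which 2 of the 3 values shown sit). Compound 4 `O=C1NC(=O)/C(=C/C(c2ccc(-c3ccc4cccc(F)c4c3)[nH]c2=O)C2CCCCC2)O1` differs from compound 3 in one place: cyclohexyl in place of pentan-3-yl on a saturated chain carbon bound to an aromatic carbon and a double-bonded chain carbon. Within the data shown here, the only measured step, an at least 5.1-fold lower number from compound 1 to compound 2 (0.71 log units; beyond the scatter), alters the five-membered ring group and not the group exchanged here, so it bears on this change only weakly. No step beyond the scatter is therefore expected, and the estimated step is a step that the limit leaves unreadable from compound 3 to compound 4. For compound 4 the expected half-life is 4 h, with an estimated range from 1.5 h to 8 h.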

Compound 4, half-life: 1.09 h
Beside the measured number, compound 4's estimate is 3.7-fold (0.56 log units) above it; measured number outside the range, below it.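

In this assay, the saturated chain carbon bound to an aromatic carbon and a double-bonded chain carbon proves sensitive to the group it carries: cyclohexyl in place of pentan-3-yl gives an at least 2.7-fold lower number from compound 3 to compound 4 (0.43 log units; beyond the scatter). The half-life thus responds to this group as well as to the five-membered ring group. Compound 3 has only a limit, so the full size of this step cannot be read: the limit of > 3 h in this assay, at which 2 of the 4 values shown sit.

The compounds shown leave open whether a cyclopentyl or tetrahydropyranyl group here would behave like pentan-3-yl or like cyclohexyl. They also leave open whether the same exchange would lower the half-life with the five-membered ring group of compound 1.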